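The compounds below may be only part of what the source reports. "The series", "measured", "known", "first", "only" and "open" are said of these compounds alone.

For the measured compounds named here, compound 3 `Nc1nc(N)c2cc(CSC(=S)N3CCN(c4ccc(F)cc4F)CC3)ccc2n1` gives 5020 nM in a functional assay on HT-29 cells (Homo sapiens) for antiproliferative activity, read by MTT assay, with a stated time of 72 h (a lower number here means a stronger inhibitor, a higher number a weaker inhibitor), the highest of the three numbers measured so far: compound 1 `Nc1nc(N)c2cc(CSC(=S)N3CCN(c4ccccc4)CC3)ccc2n1` gives 2760 nM and compound 2 `Nc1nc(N)c2cc(CSC(=S)N3CCN(c4ccc(F)cc4)CC3)ccc2n1` gives 2050 nM. Compound 4 `Nc1nc(N)c2cc(CSC(=S)N3CCN(c4ccccc4[N+](=O)[O-])CC3)ccc2n1` differs from compound 3 by 2-nitrophenyl in place of 2,4-difluorophenyl on an amine nitrogen in a ring. Going by the values given here, the steps that bear on this change are those on the same ring: a 1.8-fold higher number from compound 1 to compound 3 (0.26 log units; within the scatter), and a 2.4-fold higher number from compound 2 to compound 3 (0.39 log units; beyond the scatter). Both show that altering the substitution of this aryl group moved the number only slightly, so a similarly small step is expected here, with no firm direction; nothing measured speaks to a nitro group. Compound 4 is therefore estimated at 3000 nM, with a range from 1200 nM to 7500 nM, meaning a step of a 1.7-fold lower number from compound 3 to compound 4 (0.22 log units; within the scatter) that is expected to stay within the scatter.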

Compound 4, half-maximal inhibitory concentration: 4310 nM
The estimate for compound 4 lay 1.4-fold (0.16 log units) below the measured number, within the range that was stated.
By their numbers in this assay, from the lowest: compounds 2, 1, 4 and 3 (each within the scatter of the next, the first and the last beyond it).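

In this assay, for the compounds shown here, a nitro group on this aryl ring sits with the earlier compounds: there is a 1.2-fold lower number from compound 3 to compound 4 (0.07 log units; within the scatter) and a 1.6-fold higher number from compound 1 to compound 4 (0.19 log units; within the scatter) and neither leaves the scatter. Only a 2.1-fold higher number from compound 2 to compound 4 (0.32 log units; beyond the scatter) goes beyond it, and modestly, so the 2-nitrophenyl group is set apart from 4-fluorophenyl alone. No measurement given here explains these numbers. On these data alone, whether an amine or a carboxylic acid on this phenyl ring would move the number further remains open, as does the effect of a pyridine ring in place of the phenyl.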